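The source may report more compounds than this note shows. Statements on the series, on what has been measured and on what is new or still open speak of the compounds shown alone.

Working notes on the series. Among the measured compounds shown here, in a functional assay on SH-SY5Y cells (Homo sapiens) for antagonist activity, read by cAMP accumulation (a higher number here means a more potent compound, by a factor of ten per unit of this negative logarithm, a lower number a less potent compound), compound 1 `FC(F)(F)COc1ccc(Cc2ccc(NC3=NCCN3)cc2)cc1` gives 8.7 and compound 2 `c1cc(NC2=NCCN2)ccc1Cc1ccc(OC2CCCCC2)cc1` gives 8.6, so compound 2 stands within the scatter of the only other number available. Compound 3 `c1cc(NC2=NCCN2)ccc1Cc1ccc(OC2CCOCC2)cc1` differs from compound 2 by one change, oxan-4-yl in place of cyclohexyl on an oxygen on an aromatic ring. For the measured compounds named here, one measured step bears on this: a number 0.10 log units lower from compound 1 to compound 2 (within the scatter). Going by the values given here, that step alters the group on the same oxygen and stays within the scatter, but no measured compound carries oxan-4-yl, so it offers only indirect guidance. The downward lean below is a judgement, not a measured trend. The expected step in this assay is small and downward, a number 0.30 log units lower from compound 2 to compound 3 (within the scatter), at about the edge of the scatter. For compound 3 the estimated value is 8.3, with an expected range from 7.8 to 8.8.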

Compound 3, negative logarithm of the antagonist equilibrium constant: 8.4
Compound 3: the middle estimate sits 0.10 log units below what was measured, and the stated range covers the measured number.
By their numbers in this assay, from the lowest: compounds 3, 2 and 1 (each within the scatter of the next).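

In this assay, the first ring carrying a hetero atom at this position, oxan-4-yl in place of cyclohexyl on an oxygen on an aromatic ring, gives a number 0.20 log units lower from compound 2 to compound 3 (within the scatter); the change brings in one hydrogen-bond acceptor with the heavy-atom count unchanged. The comparison with the open-chain 2,2,2-trifluoroethyl group gives a number 0.30 log units lower from compound 1 to compound 3 (within the scatter), so the three groups shown on this oxygen, two rings and one chain, all stay within the scatter of one another. Nothing available accounts for these small steps or gives any property of these groups as measured.

On these data alone, whether this flat picture holds for a basic amine such as piperidin-4-yl, for a carboxylic acid or for a longer alkyl chain on the same oxygen remains open. Also open, as far as these compounds go, is whether a smaller group such as methyl would stay within the scatter of these three.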